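From 4-chlorobenzyl to 2,4-dichlorobenzyl

The source may report more compounds than this note shows. Statements on the series, on what has been measured and on what is new or still open speak of the compounds shown alone.

In a functional assay on HL-60 cells (Homo sapiens) for antiproliferative activity, with a stated time of 72 h (on this read-out higher numbers stand for weaker inhibition and lower numbers for stronger inhibition), compound 2 `OC[C@H]1O[C@@H](n2cnc3c(NCc4ccc(Cl)cc4)ncnc32)[C@H](O)[C@@H]1O` gives 1700 nM, and compound 1 `OC[C@H]1O[C@@H](n2cnc3c(NCc4ccc(F)cc4)ncnc32)[C@H](O)[C@@H]1O` gives 1200 nM, within the scatter of compound 2. Compound 3 `Cc1cccc(CNc2ncnc3c2ncn3[C@@H]2O[C@H](CO)[C@@H](O)[C@H]2O)c1` gives 6400 nM, the highest number of the three, and the gap to it is a 3.8-fold higher number from compound 2 to compound 3 (0.58 log units; beyond the scatter).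

Compound 4 `OC[C@H]1O[C@@H](n2cnc3c(NCc4ccc(Cl)cc4Cl)ncnc32)[C@H](O)[C@@H]1O` carries chloro in place of hydrogen on an aromatic carbon, ortho to a large group and meta to a chloro group (chloro in place of hydrogen on an aromatic carbon). Within the data shown here, no measured step adds a group in this way. The nearest evidence is the halogen exchange, a 1.4-fold higher number from compound 1 to compound 2 (0.15 log units; within the scatter), while the change of aryl group gives a 5.3-fold higher number from compound 1 to compound 3 (0.73 log units; beyond the scatter). The expected step is a 1.1-fold lower number from compound 2 to compound 4 (0.05 log units; within the scatter), with no shift beyond the scatter anticipated. Compound 4 is estimated at 1500 nM, with an expected range of 500 nM to 4500 nM.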

Compound 4, half-maximal inhibitory concentration: 96300 nM
Estimate against measurement, compound 4: 64-fold (1.81 log units) below; the measured number lies above the stated range.
By their numbers in this assay, from the lowest: compounds 1 and 2 (each within the scatter of the next); then compound 3; then compound 4.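

In this assay, chloro in place of hydrogen on this aromatic carbon, ortho to a large group and meta to a chloro group, gives a 57-fold higher number from compound 2 to compound 4 (1.75 log units; beyond the scatter), whereas the earlier exchange of halogen stayed within the scatter. The 2,4-dichlorobenzyl compound also stands apart from the other two aryl variants, with a 15-fold higher number from compound 3 to compound 4 (1.18 log units; beyond the scatter) and an 80-fold higher number from compound 1 to compound 4 (1.90 log units; beyond the scatter). Nothing measured here accounts for this large step. Open, going by these compounds, is whether the added chloro group needs the one already on the ring, and whether a methoxy group or an amine on this carbon gives a step of similar size.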